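Swapping Methoxy for Dimethylamino on a Nucleoside Core

A few compounds are considered here, and "the series" means these few. Any claim that something is new, unique, unknown or untested is made for them only; others in the source may bear on it.

Of the compounds shown here, three built on a shared sugar-bearing core have been tested in a functional assay on A549 cells (Homo sapiens), read by MTT assay, with a stated time of 72 h; a higher number here means a weaker inhibitor, a lower number a stronger inhibitor. Compound 1 `Nc1nc(N)c2c(-c3ccsc3)cn([C@@H]3O[C@H](CO)[C@@H](O)[C@H]3O)c2n1` reaches only a limit of the assay: in this assay compound 1 gives > 100000 nM. Compound 3 `O=c1[nH]cnc2c1c(-c1ccoc1)cn2[C@@H]1O[C@H](CO)[C@@H](O)[C@H]1O` likewise stops at a limit, and in this assay compound 3 gives > 20000 nM. Among the measured compounds shown here, compound 2 `COc1ncnc2c1c(-c1ccsc1)cn2[C@@H]1O[C@H](CO)[C@@H](O)[C@H]1O` is the one member with a real number: in this assay compound 2 gives 5170 nM. Compound 2 therefore stands as the only firm point in the set, since the other two values are limits rather than numbers, as the limit of > 100000 nM in this assay, at which 1 of the 3 values shown sits, and the limit of > 20000 nM in this assay, at which 1 of the 3 values shown sits, record.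

Compound 4 `CN(C)c1ncnc2c1c(-c1ccsc1)cn2[C@@H]1O[C@H](CO)[C@@H](O)[C@H]1O` has not yet been measured. It differs from compound 2 in a single place: dimethylamino in place of methoxy on an aromatic carbon. No ring is lost or gained, and the rest of the molecule is untouched, so the change is a small one at the edge of the core.

For the measured compounds named here, no measured pair in this set shows the effect of such a swap, so its size has to be guessed. The step from compound 2 to compound 4 is expected to be modest, with a 1.4-fold higher number from compound 2 to compound 4 (0.13 log units; within the scatter) estimated as a slight loss that may not exceed the usual scatter. Compound 4 is estimated at 7000 nM, with a likely range from 1800 nM to 28000 nM.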

Compound 4, half-maximal inhibitory concentration: > 20000 nM
Compound 4 was reported as a limit; the forecaster's own chance of this, stated with the estimate: 20%; at least 2.8-fold (0.45 log units) between middle value and limit.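

Among the compounds shown here, the first one-place comparison in this set shows that this aromatic carbon, on the six-membered aromatic ring with 2 nitrogen, is sensitive to what it carries: in this assay, dimethylamino in place of methoxy gives an at least 3.8-fold higher number from compound 2 to compound 4 (0.58 log units; beyond the scatter). A swap that adds one heavy atom and keeps the same count of hydrogen-bond donors and acceptors is therefore enough to lose the measurable activity of compound 2, so those counts alone do not predict the outcome here. In this assay compound 4 gives > 20000 nM, which is a limit of the assay and not a number, so the true size of the step stays unknown, and this limit is now a common result in the set: the limit of > 20000 nM in this assay, at which 2 of the 4 values shown sit.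

As far as these compounds go, it remains open whether a smaller methylamino group or a longer ethoxy group on this carbon would stay close to compound 2 or lose activity as compound 4 does. The reason for the loss is also open, and a single cell-based read-out cannot show which feature of dimethylamino is responsible.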